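Two Fluorines on the Phenyl Ring of Compound 2

This account rests on a few compounds, and the source may have more. Where it says the series, first, only, none or still open, it means among the compounds named here.

Three measured compounds share one core and differ only in the group on the aromatic nitrogen. In a functional assay on CHO cells for positive allosteric modulation of metabotropic glutamate receptor 2 (Homo sapiens), with a stated time of 30 min (on this read-out higher numbers stand for larger maximal responses and lower numbers for smaller maximal responses), compound 1 `CC(C)Cn1ccc(N2CCC(c3ccccc3)CC2)c(C#N)c1=O` gives 316%, compound 2 `N#Cc1c(N2CCC(c3ccccc3)CC2)ccn(CC2CC2)c1=O` gives 309%, and compound 3 `N#Cc1c(N2CCC(c3ccccc3)CC2)ccn(CCC2CC2)c1=O` gives 316%. Compound 2 stands lowest of these three numbers, yet the gaps to its neighbours are small: a number 7 percentage points lower from compound 1 to compound 2 (within the scatter) and a number 7 percentage points higher from compound 2 to compound 3 (within the scatter), both within the scatter, and no change at the digits printed from compound 1 to compound 3 (within the scatter) likewise.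

Compound 4 `N#Cc1c(N2CCC(c3cc(F)cc(F)c3)CC2)ccn(CC2CC2)c1=O` keeps the cyclopropyl group of compound 2 and alters the other end of the molecule: 3,5-difluorophenyl in place of phenyl on a saturated ring carbon. Going by the values given here, none of the measured steps touches that phenyl ring; all three vary the group on the aromatic nitrogen and all stay within the scatter, so no measured step bears on this change, and the expectation rests on compound 2 alone. The maximal response of compound 4 is therefore estimated at 305%, with a range from 240% to 360%. That estimate means an expected step of a number 4 percentage points lower from compound 2 to compound 4 (within the scatter).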

Compound 4, largest response reached (Emax), in percent of the reference or control that the assay uses: 234%
Compound 4: middle estimate off by 71 percentage points, on the high side; measured number outside the range, below it.
By their numbers in this assay, from the lowest: compound 4; then compounds 2, 1 and 3 (each within the scatter of the next).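

The phenyl ring on the saturated ring carbon proves to be a place where the maximal response moves: in this assay the change to 3,5-difluorophenyl gives a number 75 percentage points lower from compound 2 to compound 4 (beyond the scatter) and so goes beyond the scatter, which none of the three changes at the aromatic nitrogen did. The step comes with two added fluorine atoms and no difference in hydrogen-bond donors, hydrogen-bond acceptors or net charge, so those counts do not separate compound 2 from compound 4. No measurement at hand accounts for the step.

The compounds shown leave open how a phenyl ring carrying a single fluorine, a chlorine or a methoxy group would fare at this place. They also leave open whether the same difluoro change would give a step of similar size on the cores of compound 1 and compound 3.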